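Swapping a Carbamoyl Group for Pyridin-4-yl in Caco-2 Inhibitors

The source may report more compounds than this note shows. Statements on the series, on what has been measured and on what is new or still open speak of the compounds shown alone.

Compound 1 `COC(=O)[C@@]1(C)C[C@@H](c2coc3ccc(C)cc3c2=O)N(c2ccccc2)O1` gives 19700 nM in a functional assay on Caco-2 cells (Homo sapiens) for inhibition, read by sulforhodamine B assay, with a stated time of 48 h; on this read-out lower numbers stand for stronger inhibition and higher numbers for weaker inhibition.
Compound 2 `NC(=O)[C@H]1C[C@@H](c2coc3ccccc3c2=O)N(c2ccccc2)O1` gives > 60000 nM in this assay, which is a limit of the assay and not a number.
Compound 3 `O=C1[C@H]2[C@H](ON(c3ccccc3)[C@@H]2c2coc3ccc(F)cc3c2=O)C(=O)N1c1ccccc1` gives > 60000 nM in this assay, again a limit and not a number.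

Compound 2 therefore sits at the top of what this assay can report: its value is only a limit, and it shares that position with one of the other two compounds shown, as described in the limit of > 60000 nM in this assay, at which 2 of the 3 values shown sit. Only compound 1 returned an actual number.

Compound 4 `O=c1c([C@@H]2C[C@H](c3ccncc3)ON2c2ccccc2)coc2ccccc12` has not yet been measured. It differs from compound 2 in one place: pyridin-4-yl in place of carbamoyl on a saturated ring carbon. The carbamoyl leaves and a pyridin-4-yl enters on a saturated ring carbon of the shared core.

Going by the values given here, no step between measured compounds is available to calibrate this change, so the expectation rests on the fact that compound 2 gave only a limit. The change from compound 2 to compound 4 is expected to give a modest step toward stronger inhibition, an at least 1.5-fold lower number from compound 2 to compound 4 (0.17 log units; that floor lies within the scatter), though it may not clear the scatter. For compound 4 in this assay the estimated value is 40000 nM, expected to fall between 10000 nM and 100000 nM.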

Compound 4, half-maximal inhibitory concentration: 37000 nM
The estimate for compound 4 lay 1.1-fold (0.03 log units) above the measured number, and the stated range covers the measured number.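

Going by these compounds alone, the result gives the first reading of a change at this saturated ring carbon, next to the ring oxygen: in this assay, pyridin-4-yl in place of carbamoyl gives an at least 1.6-fold lower number from compound 2 to compound 4 (0.20 log units; that floor lies within the scatter). Going by these compounds, because the value for compound 2 is only a limit, this step is a floor and its true size remains unknown: the limit of > 60000 nM in this assay, at which 2 of the 4 values shown sit. Compound 4, with an aromatic ring on this carbon, gives a real number of 37000 nM, so this group is compatible with a measurable value. The floor alone does not place the change beyond the usual scatter.

The compounds shown leave open whether the nitrogen of pyridin-4-yl matters, which a phenyl group on this carbon would test, and whether a carboxylic acid or a primary amine here would behave more like carbamoyl or more like pyridin-4-yl. They also do not show whether the step would carry over to a shared core bearing a further group, such as a methyl or a fluorine.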